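Propyl in Place of Isopropyl on a Shared Core

The compounds below may be only part of what the source reports. "The series", "measured", "known", "first", "only" and "open" are said of these compounds alone.

Compound 2 `CCCc1nc(C)c2c(C(C)C)nnc(S)n12` is one of three close relatives tested in a functional assay for inhibition, with Homo sapiens as the target; a higher number here means a weaker inhibitor, a lower number a stronger inhibitor. Compound 1 `CCCc1nc(C)c2c(C(C)C)nnc(O)n12` carries a hydroxy group where compound 2 carries a sulfanyl group. In this assay compound 1 returns only a limit of the assay, > 48000 nM. In this assay compound 2 likewise returns only a limit, > 48000 nM. In this assay compound 3 `C=CCn1ncc2cnc(C)n2c1=S` again gives only a limit, > 48000 nM. Among the measured compounds shown here, the single step that can be drawn, a step that the two limits leave unreadable from compound 1 to compound 2, cannot be read in size, and the whole picture rests on (the limit of > 48000 nM in this assay, at which 3 of the 3 values shown sit). Compound 4 `CCCc1nnc(S)n2c(CCC)nc(C)c12` is the next relative, differing from compound 2 by propyl in place of isopropyl on an aromatic carbon. For the measured compounds named here, no measured step involves that change, and all three compounds sit at the limit, so no direction can be read from them. Compound 4 is therefore expected to remain near the limit, with an expected step that the limit leaves unreadable from compound 2 to compound 4. The estimate for compound 4 in this assay is 60000 nM, expected to lie between 20000 nM and 200000 nM.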

Compound 4, half-maximal inhibitory concentration: > 48000 nM
Compound 4 was reported as a limit; the forecaster's own chance of this, stated with the estimate: 85%; the middle value does not contradict the limit.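

In this assay, among the compounds shown here, compound 2 and compound 4 both return only a limit of the assay, so swapping isopropyl for propyl gives no step that can be read. The compounds shown leave open whether any change on the shared core yields a measurable inhibitory concentration.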